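A few compounds are considered here, and "the series" means these few. Any claim that something is new, unique, unknown or untested is made for them only; others in the source may bear on it.

In a functional assay on A-375 cells (Homo sapiens) for antiproliferative activity, read by CCK-8 assay, with a stated time of 72 h, tested at 2 uM (a lower number here means a weaker effect, a higher number a stronger effect of the compound at the concentration tested), compound 2 `Nc1ccccc1NC(=O)c1ccc(CSC(=S)N2CCN(c3ncccn3)CC2)cc1` gives 24%. Within the data shown here, only one other compound has been measured: compound 1 `Nc1ccccc1NC(=O)c1ccc(CSC(=S)N2CCN(c3ccc(F)cc3)CC2)cc1` gives 20.9%, and the two numbers lie within the scatter of each other, the step being a number 3.1 percentage points higher from compound 1 to compound 2 (within the scatter). Compound 3 `Nc1ccccc1NC(=O)c1ccc(CSC(=S)N2CCN(C3CCCCC3)CC2)cc1` has not yet been measured. It differs from compound 2 by cyclohexyl in place of pyrimidin-2-yl on an amine nitrogen in a ring. Among the measured compounds shown here, the one measured step that speaks to this change is the exchange of groups at the same ring nitrogen, which was a number 3.1 percentage points higher from compound 1 to compound 2 (within the scatter) and so within the scatter. For the measured compounds named here, a single step of that kind gives little ground for expecting movement in either direction, and the data hold no step in which an aromatic ring gives way to a saturated one. Compound 3 is therefore expected to stay close to compound 2, at a step of a number 2 percentage points lower from compound 2 to compound 3 (within the scatter), with an estimated value of 22% and a range from 8% to 38%.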

Compound 3, a percentage reported as inhibition, at one concentration (the size of the read-out at that concentration, not a potency): 31.7%
Beside the measured number, compound 3's estimate is 9.7 percentage points below it; measured number inside the range.
By their numbers in this assay, from the lowest: compounds 1, 2 and 3 (each within the scatter of the next, the first and the last beyond it).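

At the ring nitrogen, cyclohexyl is the first non-aromatic ring shown, and in this assay its exchange for pyrimidin-2-yl gives a number 7.7 percentage points higher from compound 2 to compound 3 (within the scatter) and so cannot be separated from compound 2. Its exchange for 4-fluorophenyl gives a number 10.8 percentage points higher from compound 1 to compound 3 (beyond the scatter) and is the only step among these compounds to clear the scatter, though only modestly, which shows that an aromatic ring on this nitrogen is not needed to keep the inhibition seen at this concentration. Nothing available accounts for this difference.

On these data alone, whether a smaller carbon ring such as cyclopentyl, an open chain such as n-butyl or an oxygen-containing ring such as tetrahydropyran-4-yl would read like compound 3 or like compound 1 remains open. These numbers also come from a single concentration, so they leave the potency of all three compounds open.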